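From a Cyclic Amide to an Open Ethylamide

The source may report more compounds than this note shows. Statements on the series, on what has been measured and on what is new or still open speak of the compounds shown alone.

Compound 2 `CCOc1ccc(-c2cccc(C(=O)N3CCCC3)c2)cc1` stands highest of the two compounds measured in an assay on COS-7 cells for inhibition of patatin-like phospholipase domain-containing protein 2 (Mus musculus), tested at 200 uM (on this read-out higher numbers stand for more inhibition at the one concentration tested (going by the name of the read-out) and lower numbers for less inhibition), giving 53%. Among the measured compounds shown here, its nearest neighbour, compound 1 `CCOc1ccc(-c2cccc(C(=O)O)c2)cc1`, gives 23% in this assay, and the single known step, a number 30 percentage points higher from compound 1 to compound 2 (beyond the scatter), lies beyond the scatter. Compound 3 `CCNC(=O)c1cccc(-c2ccc(OCC)cc2)c1` has not yet been measured. It differs from compound 2 in one place: ethylamino in place of pyrrolidin-1-yl on a carbonyl carbon. For the measured compounds named here, the only measured step concerns the same carbonyl carbon, where pyrrolidin-1-yl replaced hydroxy and gave a modest gain; no step between two amides is known, so that step bears on the new change only loosely, as a sign that the group on this carbonyl carbon matters to the read-out. Compound 3 keeps an amide but loses the five-membered non-aromatic ring and gains one hydrogen-bond donor, and a step of a number 11 percentage points lower from compound 2 to compound 3 (beyond the scatter) is expected, most likely a modest fall or none beyond the scatter. Compound 3 is estimated at 42%, within 22% to 60%.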

Compound 3, a percentage reported as inhibition, at one concentration (the size of the read-out at that concentration, not a potency): 62%
Estimate against measurement, compound 3: 20 percentage points below, and the stated range ends below it.
By their numbers in this assay, from the lowest: compound 1; then compounds 2 and 3 (each within the scatter of the next).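

In this assay the step to the open amide, a number 9 percentage points higher from compound 2 to compound 3 (within the scatter), shows that the five-membered non-aromatic ring of pyrrolidin-1-yl is not required on this carbonyl carbon, since ethylamino, with fewer heavy atoms and one hydrogen-bond donor, cannot be told apart from it here. The step from the acid, a number 39 percentage points higher from compound 1 to compound 3 (beyond the scatter), shows that a second amide also stands clear of hydroxy at this place, so the earlier gain is not confined to the cyclic amide. Nothing available explains these results.

On these data alone, whether a longer chain such as n-butylamino, a larger ring such as piperidin-1-yl, or an unsubstituted amino group on this carbonyl carbon would keep this level stays open. Because this assay reports a single concentration, the compounds also leave open how their potencies compare.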